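Swapping a Triazolylamino Arm for a Tetrazolylmethyl Arm

The compounds below may be only part of what the source reports. "The series", "measured", "known", "first", "only" and "open" are said of these compounds alone.

Compound 1 `CC(C)C(Nc1nnc[nH]1)c1ccc(-c2ccc3cccc(F)c3c2)[nH]c1=O` was tested in an ADME assay on microsomes from liver (Mus musculus) for metabolic stability (a higher number here means that the compound lasts longer, a lower number that the compound disappears faster), where compound 1 gives 2.42 h. Compound 2 `CCn1ncc2c(F)cc(-c3ccc(C(CC)(CC)c4nnc(C)[nH]4)c(=O)[nH]3)cc21` gives in this assay only > 3 h, which is a limit of the assay rather than a number. Going by the values given here, compound 1 therefore carries the only plain number here, while the other reading sits at the limit of > 3 h in this assay, at which 1 of the 2 values shown sits. Compound 3 `CC(C)C(Cc1nnn[nH]1)c1ccc(-c2ccc3cccc(F)c3c2)[nH]c1=O` differs from compound 1 in one place: (1H-tetrazol-5-yl)methyl in place of (4H-1,2,4-triazol-3-yl)amino on a saturated chain carbon bound to an aromatic carbon and a saturated chain carbon. Among the compounds with values here, no pair of measured compounds shows such a change, so the step is expected to stay within the usual scatter, in no particular direction. Compound 3 is expected to give 2.4 h, with a range from 1.2 h to 4.8 h, a step of a 1.0-fold lower number from compound 1 to compound 3 (0.00 log units; within the scatter).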

Compound 3, half-life: 0.853 h
Estimate against measurement, compound 3: 2.8-fold (0.45 log units) above; measured number outside the range, below it.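

In this assay, the arm on this saturated chain carbon matters: (1H-tetrazol-5-yl)methyl in place of (4H-1,2,4-triazol-3-yl)amino gives a 2.8-fold lower number from compound 1 to compound 3 (0.45 log units; beyond the scatter). The two arms hold the same atoms, joined differently, so even a rearrangement of this kind can shift the half-life at this position. Nothing measured here explains the step.

Going by these compounds, the change alters both the ring and its link to the chain, so their separate shares remain unknown. A (4H-1,2,4-triazol-3-yl)methyl arm would separate them, and a carboxylic acid at this position remains an open comparison.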